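Pyrrolidinyl at the outer ring of the core of compound 1

The compounds below may be only part of what the source reports. "The series", "measured", "known", "first", "only" and "open" are said of these compounds alone.

Compound 1 `c1ccc(NCc2ccc(CNc3ncccn3)cc2)cc1` is the reference point. In an assay on MDA-MB-231 cells for displacement of a labelled ligand from C-X-C chemokine receptor type 4 (Homo sapiens) (on this read-out lower numbers stand for an effect already at smaller amounts and higher numbers for an effect only at larger amounts of compound), compound 1 gives 10 nM, level with compound 2 `c1cnc(NCc2ccc(CNc3cccc(N4CCCC4)c3)cc2)nc1`, which in this assay gives 10 nM; together these are the two highest numbers of the three measured. Compound 3 `Clc1cccc(NCc2ccc(CNc3ncccn3)cc2)n1` is the furthest away, with 1 nM in this assay, reached by a 10-fold lower number from compound 1 to compound 3 (1.00 log units; beyond the scatter).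

Compound 4 `c1cnc(NCc2ccc(CNc3ccc(N4CCCC4)cc3)cc2)nc1` has not been measured. It differs from compound 1 in one place: pyrrolidin-1-yl in place of hydrogen on an aromatic carbon. Within the data shown here, the step that bears on this change is the one to compound 2, which also carries pyrrolidin-1-yl in place of hydrogen on an aromatic carbon of the same shared core; that step was no change at the digits printed from compound 1 to compound 2 (within the scatter). The step to compound 3 changes a different part of the core and does not bear on the present change.

On this basis no step beyond the scatter is expected in this assay for compound 4, and the estimate is no change at the digits printed from compound 1 to compound 4 (within the scatter). Compound 4 is therefore expected to give about 10 nM, within a range of 4 nM to 25 nM.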

Compound 4, effective concentration (reported as EC, without a stated level of effect): 1 nM
For compound 4 the middle estimate is 10-fold (1.00 log units) above the measured one; the measured number lies below the stated range.
By their numbers in this assay, from the lowest: compounds 3 and 4 (each within the scatter of the next); then compounds 1 and 2 (each within the scatter of the next).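

In this assay the step of pyrrolidin-1-yl in place of hydrogen, on an aromatic carbon para to a large group, is a 10-fold lower number from compound 1 to compound 4 (1.00 log units; beyond the scatter) and lies beyond the scatter. The same group on the same ring at the place it holds in compound 2 gives 10 nM while compound 4 gives 1 nM, so among these compounds the outcome of this change depends on where the group sits and not on its presence alone. Nothing at hand accounts for this difference between the two placements.

Still open, going by these compounds, is whether a different amine at the same place, such as dimethylamino or piperidin-1-yl, would give a number like that of compound 4. Also open, on these data alone, is whether the 6-chloropyridin-2-yl change seen in compound 3 would add to the pyrrolidin-1-yl change when both are present in one compound.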